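Swapping two hydroxyls for one methoxy on the hydrazone

A few compounds are considered here, and "the series" means these few. Any claim that something is new, unique, unknown or untested is made for them only; others in the source may bear on it.

Compound 1, `Cc1c(C(=O)N/N=C\c2cc(O)ccc2O)oc2cccc(O)c12`: 95500 nM
Compound 3, `Cc1c(C(=O)N/N=C\c2cc(Cl)cc(Cl)c2O)oc2cccc(O)c12`: 9590 nM
Compound 2, `Cc1c(C(=O)N/N=C\c2ccc(C(F)(F)F)cc2)oc2cccc(O)c12`: >= 40000 nM, which is a limit of the assay and not a number.

All three were tested in a functional assay on PC-3 cells (Homo sapiens) for inhibition; a lower number here means a stronger inhibitor, a higher number a weaker inhibitor. Compound 1 holds the highest of the two numbers; compound 3 lies a step below it, beyond the scatter. Compound 2 stands at the limit of >= 40000 nM in this assay, at which 1 of the 3 values shown sits. Compound 4, `COc1cccc(/C=N\NC(=O)c2oc3cccc(O)c3c2C)c1`, is not yet measured. It differs from compound 1 in one place: 3-methoxyphenyl in place of 2,5-dihydroxyphenyl on a carbon with a double bond to nitrogen. For the measured compounds named here, no measured pair shows this exact change, so the direction is open. The step from compound 1 to compound 4 is expected to be small, within the scatter: a 1.2-fold lower number from compound 1 to compound 4 (0.08 log units; within the scatter). Compound 4 is therefore estimated at 80000 nM, between 20000 nM and 300000 nM.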

Compound 4, half-maximal inhibitory concentration: >= 40000 nM
Compound 4: only a limit was reported (the forecaster's own chance of this, stated with the estimate: 45%); the middle value is on the limit's open side.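

Compound 4 returned only a limit of the assay and not a number, so the step from compound 1 to compound 4 cannot be read: the limit of >= 40000 nM in this assay, at which 2 of the 4 values shown sit.

The compounds shown leave open whether 3-methoxyphenyl in place of 2,5-dihydroxyphenyl changes the number at all.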